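The source may report more compounds than this note shows. Statements on the series, on what has been measured and on what is new or still open speak of the compounds shown alone.

In an assay on HEK293 cells for inhibition of transient receptor potential cation channel subfamily M member 8 (Homo sapiens), read by FLIPR, with stated times of 5 min and 3 min (a higher number here means a weaker inhibitor, a lower number a stronger inhibitor), compound 1 `O=C(c1sc(-c2ccccc2O)nc1O)N1CCCCO1` gives 81 nM.
In this assay compound 2 `O=C(c1sc(-c2cccc(F)c2)nc1O)N1CCCCO1` gives 167 nM.
In this assay compound 3 `CCOC(=O)c1oc(-c2ccc(Cl)cc2)nc1O` gives > 100000 nM, which is a limit of the assay and not a number.

Compound 1 thus holds the lowest of the two numbers shown, with compound 2 nearest; the single measured step, a 2.1-fold higher number from compound 1 to compound 2 (0.31 log units; beyond the scatter), changes the aromatic ring attached to the shared core and leaves the amide end untouched. Compound 4 `CCON(C)C(=O)c1sc(-c2ccccc2O)nc1O` differs from compound 1 at that amide end: a group of 5 heavy atoms (3 carbon, 1 nitrogen, 1 oxygen; no ring) in place of a group of 6 heavy atoms (4 carbon, 1 nitrogen, 1 oxygen; one six-membered non-aromatic ring with 2 hetero atoms), on a carbonyl carbon. Going by the values given here, the six-membered ring is opened into a chain of similar size carrying the same kind of atoms, and no measured step touches this part of the molecule, so none of them bears directly on the change. With no evidence pointing either way, the expectation is a step of at most modest size, kept close to compound 1 with some allowance for a weaker number. Compound 4 is therefore expected at 140 nM, within a range of 45 nM to 450 nM, meaning an expected step of a 1.7-fold higher number from compound 1 to compound 4 (0.24 log units; within the scatter).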

Compound 4, half-maximal inhibitory concentration: 1500 nM
Estimate against measurement, compound 4: 11-fold (1.03 log units) below; the whole stated range lies below it.
By their numbers in this assay, from the lowest: compound 1; then compound 2; then compound 4. At a limit, above all of these: compound 3.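

Going by these compounds alone, the amide end, which no earlier step touched, turns out to matter more in this assay than the one aromatic ring change seen so far: ethoxy(methyl)amino in place of the six-membered ring, on a carbonyl carbon, gives a 19-fold higher number from compound 1 to compound 4 (1.27 log units; beyond the scatter), a large step, whereas the ring change gave a 2.1-fold higher number from compound 1 to compound 2 (0.31 log units; beyond the scatter), a modest one. The two groups have the same counts of hydrogen-bond donors and acceptors, so those counts do not separate them here. Nothing among the data at hand explains why the number rises.

The compounds shown leave open whether the rise follows from losing the ring or from this particular chain, which a piperidine ring or a longer chain on that carbonyl carbon could help to separate. They also leave open whether the same change would have a similar effect with the 3-fluorophenyl group of compound 2.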